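The compounds below may be only part of what the source reports. "The series", "measured", "known", "first", "only" and "open" are said of these compounds alone.

Compound 1 `Cc1nc2c(cc1Nc1nc(Cl)cn([C@H](C)C3CC3)c1=O)COC2` gives "not determined" (no result reported)
Compound 2 `CCOc1nc(C)c(Nc2nc(Cl)cn([C@H](C)C3CC3)c2=O)cc1C` gives 81%
Compound 3 `Cc1cc(OC(F)F)nc(C)c1Nc1nc(Cl)cn([C@H](C)C2CC2)c1=O` gives 84%
Compound 4 `Cc1cc(Nc2nc(Cl)cn([C@H](C)C3CC3)c2=O)c(C)nc1OC(F)F` is not yet measured

Among the compounds with values here, in an ADME assay on microsomes from liver (Homo sapiens) for metabolic stability, with a stated time of 10 min (on this read-out lower numbers stand for a less stable compound and higher numbers for a more stable compound), compound 2 gives 81% and compound 3 gives 84% as the only two numbers, which lie within the scatter of each other, and compound 1 has none. The change to compound 4 is difluoromethyl in place of ethyl on an oxygen on an aromatic ring with difluoromethyl in place of ethyl on an oxygen on an aromatic ring. Within the data shown here, no measured step sizes this change. Compound 2 (at 81%) and compound 3 (at 84%) sit within the scatter of each other, so no step beyond the scatter is expected in either direction. The estimated step of a number 1 percentage points higher from compound 2 to compound 4 (within the scatter) stays within the scatter. Compound 4 is estimated at 82% with a range of 69% to 93% on this expectation.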

Compound 4, percent of the compound remaining: 86%
The estimate for compound 4 lay 4 percentage points below the measured number; the measured number falls inside the stated range.
By their numbers in this assay, from the lowest: compounds 2, 3 and 4 (each within the scatter of the next).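

In this assay, within the data shown here, ethoxy to difluoromethoxy on this aromatic ring gives a number 5 percentage points higher from compound 2 to compound 4 (within the scatter), the first measured step for this change at this place. The exchange of ethyl for difluoromethyl on this oxygen therefore leaves the percent remaining without a step beyond the scatter. No measurement shown bears on a cause for this result.

From the compounds shown here alone, whether a methyl or a longer chain on this oxygen would stay within the scatter remains open. So does the outcome of replacing the whole ethoxy group with an amine.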